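The source may hold more compounds than are shown below. What is called first, only, known or untested is meant among the compounds shown, and "the series" means these compounds.

Compound 1 `CC(C)c1c(C(=O)N(C)Cc2ccccc2)nn(-c2ccc(F)cc2)c1CC[C@@H](O)C[C@@H](O)CC(=O)O` gives 6.2 nM in an assay on microsomes from liver for inhibition of 3-hydroxy-3-methylglutaryl-coenzyme A reductase (Rattus norvegicus); a lower number here means a stronger inhibitor, a higher number a weaker inhibitor.
Compound 2 `CC(C)c1c(C(=O)N(C)Cc2cccc(F)c2)nn(-c2ccc(F)cc2)c1CC[C@@H](O)C[C@@H](O)CC(=O)O` gives 4.1 nM in this assay.
Compound 3 `CC(C)c1c(C(=O)N(C)Cc2ccc(F)c(F)c2)nn(-c2ccc(F)cc2)c1OC[C@@H](O)C[C@@H](O)CC(=O)O` gives 5.7 nM in this assay.

All three measured compounds sit close together in this assay. Among the compounds with values here, the step from compound 2 to compound 1 is the one change that is counted between measured compounds: hydrogen in place of fluoro on an aromatic carbon. Within the data shown here, its size, a 1.5-fold higher number from compound 2 to compound 1 (0.18 log units; within the scatter), stays within the scatter of the assay, so the fluoro group leaving and hydrogen entering made no step that can be read as real. Compound 3 carries a different core; the difference between the core of compound 3 and that of compound 2 is not broken down here. Compound 3 and compound 1 lie within the scatter of each other, as do compound 3 and compound 2.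

Compound 4 `CC(C)c1c(C(=O)N(C)Cc2ccc(F)cc2)nn(-c2ccc(F)cc2)c1OC[C@@H](O)C[C@@H](O)CC(=O)O` has not yet been measured. It differs from compound 3 by hydrogen in place of fluoro on an aromatic carbon. This is the same kind of change as from compound 2 to compound 1, but not the same: in compound 3 the leaving fluoro group sits ortho to a fluoro group, whereas in compound 2 the place is meta to a large group only. The step from compound 3 to compound 4 in this assay is expected to be small, a 1.2-fold higher number from compound 3 to compound 4 (0.09 log units; within the scatter), because the matching step a 1.5-fold higher number from compound 2 to compound 1 (0.18 log units; within the scatter) stayed within the scatter. Compound 4 is therefore estimated at 7 nM, with a range from 3 nM to 16 nM.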

Compound 4, half-maximal inhibitory concentration: 18 nM
Estimate against measurement, compound 4: 2.6-fold (0.41 log units) below; the whole stated range lies below it.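

In this assay, hydrogen in place of fluoro on an aromatic carbon, here 3,4-difluorobenzyl to 4-fluorobenzyl, gave a 3.2-fold higher number from compound 3 to compound 4 (0.50 log units; beyond the scatter), a modest step that can be read as real, unlike the earlier one on the other core. Even so, the two steps cannot be told apart: the same change on two cores in this assay, a 1.5-fold higher number (0.18 log units; within the scatter) from compound 2 to compound 1 and a 3.2-fold higher number (0.50 log units; beyond the scatter) from compound 3 to compound 4, 2.1-fold (0.32 log units) apart, within the scatter of two such steps

Within the data shown here, this shows that the change carries from one core to the other without a measurable difference in size, although only one of its two steps rises above the scatter, and it does not show that the steps are equal, or that either the core or the fluoro group to which the leaving fluoro sat ortho changes the size of the step, since each case rests on a single pair of compounds.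

The compounds shown leave open how chloro, methyl or methoxy would read in place of this fluoro group on the aromatic carbon. They also leave open whether the same step would hold with a group such as cyclopropyl or a longer chain in place of the isopropyl group.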